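The compounds below may be only part of what the source reports. "The series", "measured", "known", "first", "only" and "open" are said of these compounds alone.

Compound 1 `Cc1ccc(C(=O)C#Cc2cn(COCCO)c(=O)[nH]c2=O)cc1` is one of two compounds that have been measured in a functional assay on CCRF-CEM cells (Homo sapiens) for cytotoxicity (a higher number here means a weaker inhibitor, a lower number a stronger inhibitor), and in this assay compound 1 gives 700 nM. Within the data shown here, the other is compound 2 `COc1ccc(C(=O)C#Cc2cnc(O)nc2O)cc1`, which in this assay gives 2300 nM, a higher number than that of compound 1, with the gap between the two beyond the usual scatter; the two differ in more than one place, so no single step joins them. Compound 1 thus stands at the lower of the two numbers. Compound 3 `Cc1ccccc1C(=O)C#Cc1cn(COCCO)c(=O)[nH]c1=O` has the same atoms as compound 1, joined differently: 2-methylphenyl in place of 4-methylphenyl on a carbonyl carbon. Among the measured compounds shown here, no measured pair here shows what this change does, so the expectation rests on compound 1 alone. The estimated step, a 1.4-fold higher number from compound 1 to compound 3 (0.15 log units; within the scatter), is a slight weakening that may well stay within the scatter. Compound 3 is therefore expected to give about 1000 nM, likely within the range 350 nM to 3000 nM.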

Compound 3, half-maximal inhibitory concentration: 900 nM
Compound 3: the middle estimate sits 1.1-fold (0.05 log units) above what was measured, within the range that was stated.
By their numbers in this assay, from the lowest: compounds 1 and 3 (each within the scatter of the next); then compound 2.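

In this assay, among these compounds, the pair gives the first reading at this place on a carbonyl carbon: 2-methylphenyl in place of 4-methylphenyl is a 1.3-fold higher number from compound 1 to compound 3 (0.11 log units; within the scatter) and so leaves the number unchanged within the scatter. Compound 1 and compound 3 therefore cannot be told apart in this assay, and moving the methyl between these two named groups makes no measurable difference here. Nothing at hand bears on why the two groups read alike.

As far as these compounds go, whether an amine or a carboxylic acid in place of the methyl, or a longer chain such as ethyl, would also stay within the scatter of compound 1 remains open. Compound 2 differs from the others in more than one place, so what separates it from them also stays unresolved.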